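The source may hold more compounds than are shown below. What is called first, only, known or untested is meant among the compounds shown, and "the series" means these compounds.

Of the compounds shown here, three built on a shared core have been measured in an in vitro ADME assay on microsomes from liver (Homo sapiens) for metabolic stability, tested at 5 uM; on this read-out lower numbers stand for a shorter-lived compound and higher numbers for a longer-lived compound. For compound 1 `CS(=O)(=O)Nc1ccc2c(c1)S(=O)(=O)N=C(c1c(O)c(-c3ccc(Cl)s3)nn(CCC3CC3)c1=O)N2` the read-out stops at a limit of the assay, > 1 h. Compound 2 `CC(C)CCn1nc(-c2ccccc2)c(O)c(C2=NS(=O)(=O)c3cc(NS(C)(=O)=O)ccc3N2)c1=O` gives a number, 0.633 h. Compound 3 `CS(=O)(=O)Nc1ccc2c(c1)S(=O)(=O)N=C(c1c(O)c(-c3cccs3)nn(CC3CCC3)c1=O)N2` also reaches a limit of the assay, > 1 h. Thus compound 3 stands together with compound 1 at the limit of > 1 h in this assay, at which 2 of the 3 values shown sit, while compound 2, which differs from both in more than one place, sits at a measured number rather than a limit; no single step connects it to compound 3, so its value can only be set beside the others without being read as a step.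

Compound 4 `CS(=O)(=O)Nc1ccc2c(c1)S(=O)(=O)N=C(c1c(O)c(-c3cccs3)nn(CCC3CCC3)c1=O)N2`, not yet measured, differs from compound 3 in one place: cyclobutylmethyl in place of cyclobutyl on a saturated chain carbon bound to an aromatic nitrogen. For the measured compounds named here, no measured pair shows what this change does in this assay. Going by the values given here, with no such step to lean on, the expectation is that the half-life of compound 4 will move little from the limit reached by compound 3, a change of a number no higher from compound 3 to compound 4 (the limit leaves the size open) that stays within the usual scatter. Compound 4 is therefore estimated at 1 h, within a range from 0.45 h to 2.2 h, and it may well again return only a limit.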

Compound 4, half-life: > 1 h
Compound 4 ended at the assay's limit (the forecaster's own chance of this, stated with the estimate: 50%); the middle value sits exactly at the limit.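

In this assay compound 4 gives > 1 h, a limit of the assay. Compound 3 also sits at a limit, so no step can be read between compound 3 and compound 4. The compounds shown leave open how long the half-lives of compound 1, compound 3 and compound 4 actually are, and whether cyclobutylmethyl in place of cyclobutyl changes the half-life at all.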